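The source may hold more compounds than are shown below. What is called first, only, known or untested is meant among the compounds shown, and "the series" means these compounds.

Measured so far:

Compound 1, `CCOC(=O)c1c(-c2cccc(F)c2)[nH]c2cccc(OC)c2c1=O`, in a physicochemical assay for solubility, in phosphate buffer, at pH 7.4; on this read-out lower numbers stand for lower solubility and higher numbers for higher solubility: > 100000 nM
Compound 2, `CCOC(=O)c1c(-c2ccc(Cl)c(Cl)c2)[nH]c2cc(OC)ccc2c1=O`, in this assay: 17000 nM

The value for compound 1 is a limit of this assay and not a number. Compound 1 sits at the limit of > 100000 nM in this assay, at which 1 of the 2 values shown sits, so only the bottom of its range is known and the true solubility could lie anywhere beyond it. Within the data shown here, compound 2 carries a real number, 17000 nM, but it differs from compound 1 in more than one place, so no single step between the two can be drawn; the two values simply show where each stands.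

Compound 3, `CCOC(=O)c1c(-c2cccc(C)c2)[nH]c2cccc(OC)c2c1=O`, has not yet been measured in this assay. It differs from compound 1 by one exchange: methyl in place of fluoro on an aromatic carbon. The group that leaves and the one that enters are each a single heavy atom, without ring, donor or acceptor, and without charge.

Among the measured compounds shown here, no measured step fits this exchange, so the expectation rests on compound 1 alone. The step from compound 1 to compound 3 is expected to be an at least 1.2-fold lower number from compound 1 to compound 3 (0.09 log units; that floor lies within the scatter), a shift that may not exceed the scatter and may again end at the limit. Compound 3 is estimated at 80000 nM, within 20000 nM to 300000 nM.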

Compound 3, solubility: > 100000 nM
Compound 3 gave a limit, no number (the forecaster's own chance of this, stated with the estimate: 45%); at least 1.2-fold (0.09 log units) between middle value and limit.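

In this assay compound 3 gives > 100000 nM as a limit and not a number. Compound 1 sits at the same limit, so no step between compound 1 and compound 3 can be read: the limit of > 100000 nM in this assay, at which 2 of the 3 values shown sit.

On these data alone, how far compound 1 and compound 3 each lie beyond that limit, and whether methyl in place of fluoro changes the read-out at all, stays open.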